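The source may hold more compounds than are shown below. What is called first, only, known or untested is meant among the compounds shown, and "the series" means these compounds.

The series shares the core of compound 1 `C#CCNC1CCc2c(SCc3cccc(C)c3)cccc21`, and it is followed in an ADME assay on isolated protein for inhibition of Amine oxidase [flavin-containing] B (Homo sapiens); on this read-out lower numbers stand for stronger inhibition and higher numbers for weaker inhibition. Compound 1 reaches only the limit of that assay: it gives > 100000 nM, a limit rather than a number, and this is the entry that sits at the limit of > 100000 nM in this assay, at which 1 of the 3 values shown sits. Compound 2 `C#CCNC1CCc2c(NCc3cccc(C(F)(F)F)c3)cccc21` carries an amino link and a trifluoromethyl group instead, and in this assay compound 2 gives 11300 nM. Compound 3 `C#CCNC1CCc2c(SCCc3cccc(Cl)c3)cccc21` is part of the same set, and in this assay compound 3 is reported as "not determined" (no result reported), so no result is available for it. Compound 4 `C#CCNC1CCc2c(SCc3ccc(Br)cc3)cccc21` has not yet been measured. It differs from compound 1 in one place: 4-bromophenyl in place of 3-methylphenyl on a saturated chain carbon bound to a sulfur. Going by the values given here, the size of the step this change brings in this assay is not known, and the bromophenyl compound has no measured counterpart here. With compound 1 sitting at the limit shown by the limit of > 100000 nM in this assay, at which 1 of the 3 values shown sits, the step from compound 1 to compound 4 is expected to be an at least 1.6-fold lower number from compound 1 to compound 4 (0.22 log units; that floor lies within the scatter), and compound 4 is estimated to give about 60000 nM, within a range from 10000 nM to 200000 nM.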

Compound 4, half-maximal inhibitory concentration: 488 nM
For compound 4 the middle estimate is 120-fold (2.09 log units) above the measured one; the measured number lies below the stated range.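

Replacing 3-methylphenyl with 4-bromophenyl on a saturated chain carbon bound to a sulfur brings an at least 200-fold lower number from compound 1 to compound 4 (2.31 log units; beyond the scatter) in this assay. The two groups have the same counts of heavy atoms, hydrogen-bond donors and hydrogen-bond acceptors, yet this single change separates a compound at the assay limit from one with a measured number, so this position clearly matters for the read-out. Compound 1 gives > 100000 nM, which is a limit and not a number, so the step is only a floor and its full size is unknown: the limit of > 100000 nM in this assay, at which 1 of the 4 values shown sits.

The compounds shown cannot tell whether the difference follows from the bromine itself or from where the group sits on the ring, as both differ in this one change. Going by these compounds, how a plain phenyl ring, or a nitrile in place of the bromine, would read at this position also remains open.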